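A Second Chloro Group on a Shared Core

The source may report more compounds than this note shows. Statements on the series, on what has been measured and on what is new or still open speak of the compounds shown alone.

Of the compounds shown here, three have so far been tested in a functional assay on SW480 cells (Homo sapiens) for antiproliferative activity, read by MTT assay, with a stated time of 48 h; a lower number here means a stronger inhibitor, a higher number a weaker inhibitor. Compound 1 `CCCCC(CCO)n1cnc2c(Cl)ncnc21` and compound 2 `CCCCC(CCO)n1cnc2cncnc21` share a core, while compound 3 `CCCCCCC(CCO)n1cnc2c(Cl)ncnc21` carries a longer chain on the same ring system. In this assay compound 1 reaches only the limit of > 50000 nM. Compound 2 likewise sits at the limit of > 50000 nM in this assay. Among the measured compounds shown here, compound 3 gives 16700 nM in this assay, the only number among the three.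

The change from compound 2 to compound 1 is chloro in place of hydrogen on an aromatic carbon, and the step that the two limits leave unreadable from compound 2 to compound 1 cannot be read, due to the limit of > 50000 nM in this assay, at which 2 of the 3 values shown sit. For the measured compounds named here, the step of an at least 2.9-fold lower number from compound 1 to compound 3 (0.47 log units; beyond the scatter) is the one readable comparison, made by ethyl in place of hydrogen on a saturated chain carbon, five bonds along the chain from an aromatic nitrogen. The difference between the cores of compound 2 and compound 3 is not broken down here.

Compound 4 `CCCCCCC(CCO)n1cnc2c(Cl)nc(Cl)nc21` has not been measured. Its change from compound 3 is chloro in place of hydrogen on an aromatic carbon. This is the same kind of change as from compound 2 to compound 1, but the place differs: there the chloro entered next to the ring nitrogen, ortho to a fused ring, meta to a fused ring and opposite the ring nitrogen; here it enters between two ring nitrogen atoms, meta to a chloro group, meta to a fused ring and para to a fused ring. The earlier example gives no readable size, so the expectation for compound 4 rests on compound 3 alone, whose value 16700 nM is the starting point. Compound 4 is expected to give 8000 nM in this assay, a step of a 2.1-fold lower number from compound 3 to compound 4 (0.32 log units; beyond the scatter). The estimate for compound 4 is expected to span 2000 nM to 40000 nM.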

Compound 4, half-maximal inhibitory concentration: 12400 nM
Estimate against measurement, compound 4: 1.6-fold (0.19 log units) below; measured number inside the range.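

In this assay the new step is a 1.3-fold lower number from compound 3 to compound 4 (0.13 log units; within the scatter), so on the core of compound 3 a chloro group entering between two ring nitrogen atoms leaves the reading inside the usual scatter of repeated measurements. Among the compounds shown here, the earlier chloro step, from compound 2 to compound 1, cannot be read, and the two cores therefore offer no pair of sizes to set side by side, due to the assay limit: the limit of > 50000 nM in this assay, at which 2 of the 4 values shown sit. The two chloro groups also enter at different places on the ring, so this series does not show the same change carried from one core to another, and a single readable step on one core says nothing about how that change would read on the core of compound 1.

The compounds shown carry only hydrogen or chloro at the carbon between two ring nitrogen atoms, which leaves open whether an amine, a methoxy group or a nitrile there would give a step from compound 3 that stands clear of the scatter. Also open, going by these compounds, is how a longer chain than that of compound 3 would read in this assay, with or without the second chloro group.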